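The source may report more compounds than this note shows. Statements on the series, on what has been measured and on what is new or still open speak of the compounds shown alone.

The series was tested in a functional assay on Calu-1 cells (Homo sapiens) for cytotoxicity, read by resazurin assay, with a stated time of 72 h; on this read-out lower numbers stand for stronger inhibition and higher numbers for weaker inhibition. Compound 1 `O=C(/C=C/c1ccc(OCCCCO[N+](=O)[O-])c(O)c1)OCCCCO[N+](=O)[O-]` gives only a limit in this assay, > 50000 nM (the limit of > 50000 nM in this assay, at which 1 of the 3 values shown sits). Compound 2 `O=C(/C=C/c1ccc(O)c(O)c1)OCc1c(-c2ccccc2)no[n+]1[O-]` gives 7680 nM in this assay, and compound 3 `COc1cc(/C=C/C(=O)OCc2c(-c3ccccc3)no[n+]2[O-])ccc1O` gives 22900 nM. Between these two stands (methyl in place of hydrogen on an oxygen on an aromatic ring), and the measured step is a 3.0-fold higher number from compound 2 to compound 3 (0.47 log units; beyond the scatter). How the core of compound 1 differs from the core of compound 2 is not broken down here. Compound 4 `COc1cc(/C=C/C(=O)OCCCCO[N+](=O)[O-])ccc1OCCCCO[N+](=O)[O-]` has not yet been measured; it differs from compound 1 by methyl in place of hydrogen on an oxygen on an aromatic ring, the same change at the same place. The expectation for it rests on compound 3 sitting higher than compound 2 after a 3.0-fold higher number from compound 2 to compound 3 (0.47 log units; beyond the scatter). The step is expected to be a step that the limit leaves unreadable from compound 1 to compound 4. Compound 4 is therefore estimated at 100000 nM, most likely reported again only as a limit, within a range from 50000 nM to 300000 nM.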

Compound 4, half-maximal inhibitory concentration: > 50000 nM
Compound 4: no number, only a limit; the forecaster's own chance of this, stated with the estimate: 90%; the middle value lies beyond the limit too.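

Compound 1 and compound 4 each give only a limit in this assay, so no step between them can be read: the limit of > 50000 nM in this assay, at which 2 of the 4 values shown sit.

On these data alone, whether hydroxy to methoxy alters the cytotoxicity of this pair, as it does from compound 2 to compound 3, stays open.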